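Working notes on a carboxylic acid series, compounds 1 to 4

The source may hold more compounds than are shown below. What is called first, only, known or untested is meant among the compounds shown, and "the series" means these compounds.

Measured so far:
compound 1 `Cc1c(OCCCCOc2ccccc2C(=O)O)ccc(C(=O)CC2CCCC2)c1C`: "not determined" (no result reported)
compound 2 `Cc1c(OCCCCOc2ccccc2C(=O)O)ccc(C(=O)CC2CCCC2)c1O`: "not determined" (no result reported)
compound 3 `CCCC(=O)c1ccc(OCCCCOc2cccc(C(=O)O)c2C)c(C)c1O`: > 10000 nM

In an assay on HEK293 cells for positive allosteric modulation of metabotropic glutamate receptor 3 (Rattus norvegicus), read by thallium flux, with a stated time of 2.5 min (on this read-out lower numbers stand for an effect already at smaller amounts and higher numbers for an effect only at larger amounts of compound), compound 2 has no single number. Of the two other entries, one is a result without a number and one is a limit rather than a number. For the measured compounds named here, compound 3 sits at that limit, which is the limit of > 10000 nM in this assay, at which 1 of the 3 values shown sits, so no measured value fixes any point, and no step between measured compounds can be given.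

Compound 4 `Cc1ccc(C(=O)O)cc1OCCCCOc1ccc(C(=O)CC2CCCC2)c(O)c1C` is the next compound and differs from compound 2 by 5-carboxy-2-methylphenyl in place of 2-carboxyphenyl on an oxygen on a saturated carbon. Going by the values given here, with no measured step available, no direction for the change from compound 2 to compound 4 can be read from the data; the only number of any kind is the limit for compound 3, so the expectation rests on that limit alone.

Compound 4 is expected to give about 8000 nM in this assay, with an estimated range from 1500 nM to 40000 nM, and a sizeable chance that only a limit is reported.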

Compound 4, half-maximal effective concentration: > 10000 nM
Compound 4: only a limit was reported; the forecaster's own chance of this, stated with the estimate: 60%; middle value at least 1.2-fold (0.09 log units) away from the limit.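

Compound 4 gives only a limit and compound 2 has no single number, so no step between compound 2 and compound 4 can be read: the limit of > 10000 nM in this assay, at which 2 of the 4 values shown sit.

The compounds shown leave open how 5-carboxy-2-methylphenyl compares with 2-carboxyphenyl, and whether any compound in the series reaches a single measured value.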